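A few compounds are considered here, and "the series" means these few. Any claim that something is new, unique, unknown or untested is made for them only; others in the source may bear on it.

Compound 1 `C#CCOc1ccc(-c2cc(-c3ccc(OCC#C)c(OCC)c3)nc(-c3ccccc3)n2)cc1`: "not active" (no number reported) in an assay on BTI-TN-5B1-4 cells for inhibition of Amine oxidase [flavin-containing] A (Homo sapiens), read by fluorescence and Amplex Red, using microsomes, with a stated time of 30 min; on this read-out lower numbers stand for stronger inhibition and higher numbers for weaker inhibition
Compound 2 `C#CCOc1ccc(-c2cc(-c3ccc(OCC#C)cc3)nc(N)n2)cc1`: 32100 nM

In this assay, for the measured compounds named here, compound 2 gives 32100 nM, the only number in the set; compound 1 carries no single number. Going by the values given here, no pair of measured compounds differing at one position exists, so no measured step is known. Compound 3 `C#CCOc1ccc(-c2cc(-c3ccc(OCC#C)c(OCC)c3)nc(N)n2)cc1` differs from compound 2 by ethoxy in place of hydrogen on an aromatic carbon. Without a measured step for this change, the expectation is a small loss or nothing beyond the scatter, with a real chance that only a limit is reported. For compound 3 the estimated value is 45000 nM, range 15000 nM to 150000 nM, an expected step of a 1.4-fold higher number from compound 2 to compound 3 (0.15 log units; within the scatter).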

Compound 3, half-maximal inhibitory concentration: "not active" (no number reported)
For compound 3 the study gives words and no number; there is nothing to compare the estimate with.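

No step can be read between compound 2 and compound 3: compound 3 carries words and no number. Going by these compounds, what ethoxy in place of hydrogen does to the number stays open, and no evidence bears on this result.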